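Swapping a pyridine for a methylphenyl on a piperazine

A few compounds are considered here, and "the series" means these few. Any claim that something is new, unique, unknown or untested is made for them only; others in the source may bear on it.

Measured compounds:
compound 1, `CCN(Cc1ccncc1)C(=S)SCc1ccc(C(=O)Nc2ccccc2N)cc1`, 77.7%
compound 2, `Nc1ccccc1NC(=O)c1ccc(CSC(=S)N2CCN(c3ccncc3)CC2)cc1`, 77.4%
compound 3, `COC(=O)c1ccc2c(c1)CCN2C(=S)SCc1ccc(C(=O)Nc2ccccc2N)cc1`, 60.1%

Of the compounds shown here, three share one core and have been tested in a functional assay on HeLa cells (Homo sapiens) for antiproliferative activity, read by CCK-8 assay, with a stated time of 72 h, tested at 8 uM; a higher number here means a stronger effect of the compound at the concentration tested, a lower number a weaker effect. Compound 1 gives 77.7%, compound 2 gives 77.4% and compound 3 gives 60.1%. Compound 2 stands second highest of the three numbers, but its gap to compound 1 lies within the scatter, so the two cannot be told apart; its gap to compound 3 is larger and lies beyond the scatter.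

Compound 4, `Cc1ccc(N2CCN(C(=S)SCc3ccc(C(=O)Nc4ccccc4N)cc3)CC2)cc1`, has not yet been measured. It differs from compound 2 in one place: 4-methylphenyl in place of pyridin-4-yl on an amine nitrogen in a ring. For the measured compounds named here, no measured pair shows this exact change, so there is no step from which its effect could be read. Given that compound 1 and compound 2, which differ in more than one place, give numbers within the scatter of each other, a small step, in either direction or none beyond the scatter, is expected from compound 2 to compound 4, namely a number 3.4 percentage points lower from compound 2 to compound 4 (within the scatter). Compound 4 is therefore expected to give about 74%, between 58% and 88%.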

Compound 4, a percentage reported as inhibition, at one concentration (the size of the read-out at that concentration, not a potency): 24%
Compound 4: middle estimate off by 50 percentage points, on the high side; the whole stated range lies above it.
By their numbers in this assay, from the lowest: compound 4; then compound 3; then compounds 2 and 1 (each within the scatter of the next).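

In this assay, putting 4-methylphenyl in place of pyridin-4-yl on the amine nitrogen in the ring gives a number 53.4 percentage points lower from compound 2 to compound 4 (beyond the scatter). The earlier compounds shown here included no pair differing in one place, so they could not show how much this position matters; this step shows that exchanging one six-membered aromatic ring for another here can change the read-out strongly, even though the group gains only a little in size. Nothing measured here gives a reason for this step.

On these data alone, the swap removes the ring nitrogen and adds a methyl group together, so the effect of each alone remains open. A plain phenyl on the same nitrogen would separate the two, and a pyridin-3-yl would test whether the place of the ring nitrogen counts.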